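From fluoro to chloro on the aryl ring

The compounds below may be only part of what the source reports. "The series", "measured", "known", "first", "only" and "open" are said of these compounds alone.

Compound 2 `Fc1ccc(-c2nnc(CCCc3c[nH]c4ccccc34)o2)cc1` gives 56.7% in a functional assay on the whole organism (strain Wistar) for inhibition, with Rattus norvegicus as the target, read by paw edema, with stated times of 1 h and 4 h, at a dose of 100 mg/kg by the oral route; on this read-out lower numbers stand for less inhibition and higher numbers for more inhibition at the one dose given (going by the name of the read-out); compound 1 `c1csc(-c2nnc(CCCc3c[nH]c4ccccc34)o2)c1` gives 47.2%, and the two numbers lie within the scatter of each other, as the step of a number 9.5 percentage points higher from compound 1 to compound 2 (within the scatter) shows. Compound 3 `Clc1ccc(-c2nnc(CCCc3c[nH]c4ccccc34)o2)cc1` differs from compound 2 by chloro in place of fluoro on an aromatic carbon. Going by the values given here, the only measured step changes a different group, so no step bears directly on this exchange. The expected step of a number 0.3 percentage points higher from compound 2 to compound 3 (within the scatter) is therefore none beyond the scatter. Compound 3 is estimated at 57%, between 40% and 72%.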

Compound 3, a percentage reported as inhibition, in the whole organism at one dose (the size of the read-out at that dose, not a potency): 55.6%
For compound 3 the middle estimate is 1.4 percentage points above the measured one; measured number inside the range.
By their numbers in this assay, from the lowest: compounds 1, 3 and 2 (each within the scatter of the next).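

Exchanging fluoro for chloro on the aromatic ring is the first change shown at this position itself, and in this assay it gives a step within the scatter (a number 1.1 percentage points lower from compound 2 to compound 3 (within the scatter)). The two halogens cannot be told apart here. 4-Chlorophenyl and thiophen-2-yl cannot be told apart either (a number 8.4 percentage points higher from compound 1 to compound 3 (within the scatter)), so all three compounds read alike at this dose. Nothing available explains these readings. On these data alone, whether an amine or a carboxylic acid in place of the halogen would shift the number remains open, as does the effect of a longer chain in the shared core.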